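Working notes on the carbonyl substituent, compound 3 to compound 4

The source may report more compounds than this note shows. Statements on the series, on what has been measured and on what is new or still open speak of the compounds shown alone.

Among the compounds with values here, the three compounds measured so far share one core and differ in the group on the carbonyl attached to the amide-type nitrogen. In a functional assay on SK-BR-3 cells (Homo sapiens) for inhibition, read by MTT assay, with a stated time of 2 days, tested at 10 uM (on this read-out lower numbers stand for less inhibition of growth and higher numbers for more inhibition of growth at the one concentration tested), compound 1 `CNC(=O)c1cc(Oc2ccc3nc(NC(=O)Nc4ccc(N5CCN(C)CC5)cc4)sc3c2)ccn1` gives 30.5%, compound 2 `CNC(=O)c1cc(Oc2ccc3nc(NC(=O)Nc4ccc(Cl)cc4)sc3c2)ccn1` gives 50.8%, and compound 3 `CNC(=O)c1cc(Oc2ccc3nc(NC(=O)c4cccc(F)n4)sc3c2)ccn1` gives 12.5%. Compound 3 stands lowest of the three numbers, beyond the scatter from both of the others. Of the measured steps, a number 20.3 percentage points higher from compound 1 to compound 2 (beyond the scatter) came with chloro in place of 4-methylpiperazin-1-yl on an aromatic carbon, and a number 38.3 percentage points lower from compound 2 to compound 3 (beyond the scatter) came with 6-fluoropyridin-2-yl in place of (4-chlorophenyl)amino on a carbonyl carbon.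

Compound 4 `CNC(=O)c1cc(Oc2ccc3nc(NC(=O)Nc4ccc(F)cc4)sc3c2)ccn1` is not yet measured. It differs from compound 3 by (4-fluorophenyl)amino in place of 6-fluoropyridin-2-yl on a carbonyl carbon. Within the data shown here, the step that bears on it directly is the one from compound 2 to compound 3, which this change largely reverses, with fluoro instead of chloro on the entering group; compound 1 and compound 2 together show the spread between two ureas of this core. A large upward step is therefore expected, a number 32.5 percentage points higher from compound 3 to compound 4 (beyond the scatter). Compound 4 is estimated at 45%, within a range from 28% to 62%.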

Compound 4, percent growth inhibition at one concentration: 14.2%
Estimate against measurement, compound 4: 30.8 percentage points above, and the stated range ends above it.
By their numbers in this assay, from the lowest: compounds 3 and 4 (each within the scatter of the next); then compound 1; then compound 2.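

The change on the carbonyl carbon has no readable effect in this assay: (4-fluorophenyl)amino in place of 6-fluoropyridin-2-yl gives a number 1.7 percentage points higher from compound 3 to compound 4 (within the scatter). The urea linkage alone therefore does not secure the higher numbers seen with compound 1 and compound 2, and the large step from compound 2 to compound 3 cannot be taken as a general difference between these two kinds of carbonyl substituent. Among the three ureas, the group on the aromatic carbon carries the difference, with a number 36.6 percentage points lower from compound 2 to compound 4 (beyond the scatter) for fluoro in place of chloro and a number 16.3 percentage points lower from compound 1 to compound 4 (beyond the scatter) for fluoro in place of 4-methylpiperazin-1-yl, and no measurement shown here explains either step.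

The compounds shown leave open whether the higher number is particular to chloro or also appears with other groups on that aromatic carbon, such as bromo, methyl or methoxy, or with an unsubstituted phenyl ring. They also leave open whether a (4-chlorophenyl)carbonyl group on the same nitrogen would separate the effect of the amino nitrogen from that of the chloro group.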